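The source may hold more compounds than are shown below. What is called first, only, known or untested is meant among the compounds shown, and "the series" means these compounds.

Measured so far:
- compound 1 `CCCCC(Sc1ccc(OCCCOc2ccc(Cl)cc2OC)cc1)C(=O)O`: in an assay on isolated protein for inhibition of Polyunsaturated fatty acid 5-lipoxygenase (Homo sapiens), read by HPLC, with a stated time of 15 min, in the presence of a further agent that is not named here (a higher number here means a weaker inhibitor, a lower number a stronger inhibitor), compound 1 gives > 10000 nM
- compound 2 `CCCCC(Sc1ccc(OCCCOc2cccc(C(F)(F)F)c2)cc1)C(=O)O`: in this assay compound 2 gives 1600 nM

The value of compound 1 is a limit of the assay, not a number. Compound 2 therefore holds the only number shown. Going by the values given here, the single measured step, an at least 6.2-fold lower number from compound 1 to compound 2 (0.79 log units; beyond the scatter), rests on that limit (the limit of > 10000 nM in this assay, at which 1 of the 2 values shown sits), so its true size is unknown. Compound 3 `CCCCC(Sc1ccc(OCCCOc2ccc(C)cc2)cc1)C(=O)O` differs from compound 2 by 4-methylphenyl in place of 3-(trifluoromethyl)phenyl on an oxygen on a saturated carbon. Among the compounds with values here, no measured step covers this change, so the expectation is loose: a modest weakening, a 2.2-fold higher number from compound 2 to compound 3 (0.34 log units; beyond the scatter), is expected. Compound 3 is estimated at 3500 nM, within 1200 nM to 10000 nM.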

Compound 3, half-maximal inhibitory concentration: 5200 nM
Compound 3: the middle estimate sits 1.5-fold (0.17 log units) below what was measured; the measured number falls inside the stated range.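

Compound 3 gives this position a second true number, so a change of group here can now be sized: in this assay there is a 3.3-fold higher number from compound 2 to compound 3 (0.51 log units; beyond the scatter) with 4-methylphenyl in place of 3-(trifluoromethyl)phenyl on an oxygen on a saturated carbon. The data also hold an at least 1.9-fold lower number from compound 1 to compound 3 (0.28 log units; that floor lies within the scatter) as a floor only. Compound 1 holds a limit of the assay and not a number: the limit of > 10000 nM in this assay, at which 1 of the 3 values shown sits.

The step from 3-(trifluoromethyl)phenyl to 4-methylphenyl changes both the group on the ring and its place, and the compounds shown cannot tell these two apart. As far as these compounds go, how a plain phenyl or a ring carrying a nitrile would compare stays open.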